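This account rests on a few compounds, and the source may have more. Where it says the series, first, only, none or still open, it means among the compounds named here.

Compound 1, `O=C1c2c[n+]([O-])c3ccccc3c2C(=O)c2c1c1ccccc1n2CCCCN1CCCCC1`, gives 150 nM in a functional assay on MCF7 cells (Homo sapiens) for cytotoxicity, read by MTT assay, with a stated time of 72 h; on this read-out higher numbers stand for weaker inhibition and lower numbers for stronger inhibition.
Compound 2, `CN(C)CCCCn1c2c(c3ccccc31)C(=O)c1c[n+]([O-])c3ccccc3c1C2=O`, gives 220 nM.
Compound 3, `O=C1c2c[n+]([O-])c3ccccc3c2C(=O)c2c1c1ccccc1n2CCN1CCCC1`, gives 320 nM.

Among these three numbers compound 3 stands highest: a 2.1-fold higher number from compound 1 to compound 3 (0.33 log units; beyond the scatter), whereas a 1.5-fold higher number from compound 2 to compound 3 (0.16 log units; within the scatter). Compound 4, `O=C1c2c[n+]([O-])c3ccccc3c2C(=O)c2c1c1ccccc1n2Cc1cn(C[C@H](O)CO)nn1`, differs from compound 3 by 1-(2,3-dihydroxypropyl)-1H-1,2,3-triazol-4-yl in place of (pyrrolidin-1-yl)methyl on a saturated chain carbon bound to an aromatic nitrogen. Among the compounds with values here, none of the measured steps bears directly on this change: a 1.5-fold higher number from compound 1 to compound 2 (0.17 log units; within the scatter), a 2.1-fold higher number from compound 1 to compound 3 (0.33 log units; beyond the scatter) and a 1.5-fold higher number from compound 2 to compound 3 (0.16 log units; within the scatter) each alter only the group at the end of the chain and all remain small. Within the data shown here, no measured step brings in a 1-(2,3-dihydroxypropyl)-1H-1,2,3-triazol-4-yl group, so the direction is uncertain; a modest rise in this assay is expected. Compound 4 is therefore estimated at 700 nM (range 200 nM to 2500 nM), an expected step of a 2.2-fold higher number from compound 3 to compound 4 (0.34 log units; beyond the scatter).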

Compound 4, half-maximal inhibitory concentration: > 1000 nM
Compound 4 ended at the assay's limit; the forecaster's own chance of this, stated with the estimate: 5%; middle value at least 1.4-fold (0.15 log units) from the limit.
By their numbers in this assay, from the lowest: compounds 1, 2 and 3 (each within the scatter of the next, the first and the last beyond it). At a limit, above all of these: compound 4.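

Compound 4 gives > 1000 nM in this assay, which is a limit of the assay and not a number. Putting 1-(2,3-dihydroxypropyl)-1H-1,2,3-triazol-4-yl on the saturated chain carbon bound to an aromatic nitrogen gives steps beyond the scatter: an at least 3.1-fold higher number from compound 3 to compound 4 (0.49 log units; beyond the scatter), an at least 4.5-fold higher number from compound 2 to compound 4 (0.65 log units; beyond the scatter) and an at least 6.6-fold higher number from compound 1 to compound 4 (0.82 log units; beyond the scatter). Among the amine-ended chains, the largest step was a 2.1-fold higher number from compound 1 to compound 3 (0.33 log units; beyond the scatter), so this change shows a clearly larger effect on the number.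

The compounds shown leave open how far past the limit compound 4 lies. They also leave open which part of the change carries the step, the triazole or the two hydroxyl groups; a triazole bearing a dimethylaminoethyl chain would separate these.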